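The source may hold more compounds than are shown below. What is called first, only, known or untested is meant among the compounds shown, and "the series" means these compounds.

Measured in a functional assay on A-431 cells (Homo sapiens) for inhibition, read by sulforhodamine B assay, with a stated time of 2 days; a lower number here means a stronger inhibitor of growth, a higher number a weaker inhibitor of growth:
- compound 1 `Cc1c(C#N)c(NCCO)nc2nc(NCCO)nc(N)c12`: 31900 nM
- compound 2 `N#Cc1cc2c(N)nc(NCCO)nc2nc1NCCO`: 6250 nM

Not yet measured:
- compound 3 `N#Cc1cc2c(N)ncnc2nc1NCCO`

Of the two measured compounds, compound 2 has the lower number, at 6250 nM, and is the stronger inhibitor of growth in this assay. The next change leads to compound 3: hydrogen in place of (2-hydroxyethyl)amino on an aromatic carbon. In words, this is hydrogen in place of (2-hydroxyethyl)amino on an aromatic carbon.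

Among the compounds with values here, only one measured step bears on this, and only loosely: a 5.1-fold lower number from compound 1 to compound 2 (0.71 log units; beyond the scatter). There too hydrogen enters on an aromatic carbon, but it replaces methyl, at another carbon of the core. That step was modest and lay beyond the scatter. Within the data shown here, no measured pair shows the loss of a (2-hydroxyethyl)amino group, so the direction is weakly held. A step of no greater size is expected in this assay, leaning towards a lower number, though a higher one is not excluded.

The expected step is a 2.1-fold lower number from compound 2 to compound 3 (0.32 log units; beyond the scatter). For compound 3 the estimated value is 3000 nM, with an expected range of 600 nM to 15000 nM.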

Compound 3, concentration for 50% growth inhibition: 26600 nM
The estimate for compound 3 lay 8.9-fold (0.95 log units) below the measured number, outside the stated range (above it).
By their numbers in this assay, from the lowest: compound 2; then compounds 3 and 1 (each within the scatter of the next).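

In this assay, hydrogen in place of (2-hydroxyethyl)amino on the aromatic carbon between two ring nitrogen atoms gives a 4.3-fold higher number from compound 2 to compound 3 (0.63 log units; beyond the scatter) and so marks this position as one where the group cannot be dropped without loss: compound 2, which carries it, is the stronger inhibitor of growth of the pair. The earlier step, a 5.1-fold lower number from compound 1 to compound 2 (0.71 log units; beyond the scatter) with methyl leaving at another carbon of the core, ran the opposite way, so hydrogen entering the core has no single direction in this series; the outcome goes with the place and with the group that leaves. With only these two steps, each seen once, this holds for compounds 1, 2 and 3 alone.

Open, from the compounds shown here alone, is which part of the (2-hydroxyethyl)amino group carries the difference, a question that a methylamino group, a longer chain such as 3-hydroxypropylamino, or a plain amine at this carbon would address. Nothing in the data on hand gives a reason for the direction of either step.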